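The compounds below may be only part of what the source reports. "The series", "measured", "known", "first", "only" and "open" are said of these compounds alone.

Compound 1: `Cc1cc(NC(=O)Nc2ccc(N)cc2)c2ccccc2n1`, 530 10^-6 cm/s
Compound 2: `Cc1cc(NC(=O)Nc2ccc(O)cc2)c2ccccc2n1`, 3 10^-6 cm/s

In an ADME assay for permeability, using PAMPA, at pH 7.4 (on this read-out lower numbers stand for lower permeability and higher numbers for higher permeability), compound 2 stands lowest of the two measured numbers; compound 1 gives 530 10^-6 cm/s, and the step of a 180-fold lower number from compound 1 to compound 2 (2.25 log units; beyond the scatter) separates them. Compound 3, `Cc1cc(NC(=O)Nc2ccccc2N)c2ccccc2n1`, is not yet measured. It differs from compound 2 by 2-aminophenyl in place of 4-hydroxyphenyl on an amide-type nitrogen. Among the measured compounds shown here, the only measured step bears on this change, because a 180-fold lower number from compound 1 to compound 2 (2.25 log units; beyond the scatter) came from putting a hydroxy in place of an amino on an aromatic carbon, and compound 3 puts an amino back in place of the hydroxy. A large rise is therefore expected. Compound 3 is expected to show a 100-fold higher number from compound 2 to compound 3 (2.00 log units; beyond the scatter). Compound 3 is estimated at 300 10^-6 cm/s, with a range from 60 10^-6 cm/s to 900 10^-6 cm/s.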

Compound 3, apparent permeability: 300 10^-6 cm/s
Compound 3: the middle estimate sits on the measured number at the digits printed; the measured number falls inside the stated range.
By their numbers in this assay, from the lowest: compound 2; then compounds 3 and 1 (each within the scatter of the next).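

In this assay, 2-aminophenyl in place of 4-hydroxyphenyl on the amide-type nitrogen gives a 100-fold higher number from compound 2 to compound 3 (2.00 log units; beyond the scatter), so a high number is seen with the amino group in two different ring placements. Changing only that placement, 2-aminophenyl in place of 4-aminophenyl, gives a 1.8-fold lower number from compound 1 to compound 3 (0.25 log units; within the scatter), and this small step does not separate the two aminophenyl compounds. No measurement shown here explains these numbers. As far as these compounds go, what a methylamino group, a methoxy group or a carboxylic acid would give in place of the amino group of compound 3 remains open.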